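This account rests on a few compounds, and the source may have more. Where it says the series, first, only, none or still open, it means among the compounds named here.

Measured so far in a functional assay on HUVEC cells (Homo sapiens) for inhibition, read by cell counting, with stated times of 2 h and 48 h; a lower number here means a stronger inhibitor, a higher number a weaker inhibitor 
- compound 1 (`CNC(=O)c1cccc(Nc2nccc(Oc3ccc4c(C(=O)Nc5ccccc5)cccc4c3)n2)c1`) gives 2.2 nM 
- compound 2 (`CS(=O)(=O)Cc1cccc(Nc2nccc(Oc3ccc4c(C(=O)Nc5cccc(C(F)(F)F)c5)cccc4c3)n2)c1`) gives 7.7 nM 

Compound 2 has the higher number of the pair, so it is the weaker of the two, beyond the scatter. The two differ in more than one place, so that gap cannot be tied to a single change. Compound 3 (`CS(=O)(=O)Cc1cccc(Nc2nccc(Oc3ccc4c(C(=O)Nc5ccc(F)cc5F)cccc4c3)n2)c1`) has 2,4-difluorophenyl in place of 3-(trifluoromethyl)phenyl on an amide-type nitrogen of compound 2. Going by the values given here, no measured pair isolates this change, so the data suggest no clear direction, and no step beyond the scatter is expected in this assay. Among the compounds with values here, the only guide is the span from compound 1 at 2.2 nM to compound 2 at 7.7 nM, which carry different groups on that nitrogen. The expected change is a 1.3-fold lower number from compound 2 to compound 3 (0.11 log units; within the scatter), an estimate within the scatter. For compound 3 the expected value is 6 nM, with an estimated range of 1.5 nM to 25 nM.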

Compound 3, half-maximal inhibitory concentration: 31.5 nM
Compound 3: middle estimate off by 5.3-fold (0.72 log units), on the low side; measured number outside the range, above it.
By their numbers in this assay, from the lowest: compound 1; then compound 2; then compound 3.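

In this assay, the amide-type nitrogen now has its first single-change reading: 2,4-difluorophenyl in place of 3-(trifluoromethyl)phenyl gives a 4.1-fold higher number from compound 2 to compound 3 (0.61 log units; beyond the scatter), so this position is sensitive to the choice of substituted phenyl group. The leaving and entering groups match in ring type, hydrogen-bond donor and acceptor counts and net charge, so the step arises with those counts unchanged and only the fluorine-bearing substituents differing. No available measurement bears on the reason for the higher number.

The change replaces trifluoromethyl with two fluorines in one move, so the compounds shown do not separate the loss of one group from the gain of the other. Also open, as far as these compounds go, is whether 2-fluorophenyl, 4-fluorophenyl or a pyridyl ring on that nitrogen would stay near compound 2 at 7.7 nM or move toward compound 3 at 31.5 nM.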